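The source may hold more compounds than are shown below. What is called first, only, known or untested is meant among the compounds shown, and "the series" means these compounds.

Working notes on the series, read in a physicochemical assay for solubility; a higher number here means a more soluble compound, a lower number a less soluble compound. Compound 1 `O=S(=O)(Nc1nccs1)c1ccc2c(c1)OCC[C@H]2c1ccc(C(F)(F)F)cc1-c1nccs1` gives 7000 nM, compound 2 `Cc1nc(-c2cc(C(F)(F)F)ccc2[C@H]2CCOc3cc(S(=O)(=O)Nc4ncc(F)cn4)ccc32)co1` gives 281000 nM, and compound 3 `Cc1nc(-c2cc(C(F)(F)F)ccc2[C@@H]2CCOc3cc(S(=O)(=O)Nc4nccs4)ccc32)co1` gives 130000 nM. Compound 3 therefore holds the second highest of the three numbers, lower than compound 2 by a margin just beyond the scatter and far higher than compound 1.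

The next structure is compound 4 `Cc1nc(-c2cc(C(F)(F)F)ccc2[C@H]2CCOc3cc(S(=O)(=O)Nc4nccs4)ccc32)co1`, and the comparison with compound 3 is the two compounds have the same atoms and bonds and differ only in configuration as drawn: 1 of 1 stereo elements differ; a stereocentre at a saturated ring carbon is drawn S in compound 3 and R in compound 4: a stereocentre at a saturated ring carbon is drawn S in compound 3 and R in compound 4. The same atoms and bonds are present in both.

Only one measured step connects two of these compounds: a 19-fold higher number from compound 1 to compound 3 (1.27 log units; beyond the scatter), with 2-methyl-1,3-oxazol-4-yl in place of 1,3-thiazol-2-yl on an aromatic carbon. That large step comes from a change of group, whereas no group changes here, so its size does not carry over. For the measured compounds named here, no measured pair isolates a change of configuration alone. With nothing entering or leaving, no step beyond the scatter is expected, and compound 3 is the anchor.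

The estimated step is a 1.1-fold higher number from compound 3 to compound 4 (0.03 log units; within the scatter). For compound 4 the expected value is 140000 nM, with an estimated range of 70000 nM to 270000 nM.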

Compound 4, solubility: 61000 nM
The estimate for compound 4 lay 2.3-fold (0.36 log units) above the measured number; measured number outside the range, below it.
By their numbers in this assay, from the lowest: compound 1; then compound 4; then compound 3; then compound 2.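

In this assay, the configuration at the saturated ring carbon is not neutral: the series shows a 2.1-fold lower number from compound 3 to compound 4 (0.33 log units; beyond the scatter), and this step can be assigned to that stereocentre alone because of what separates the pair: the fact that compounds 3 and 4 differ only in the configuration as drawn. For the compounds shown here, until now, the only readable step was a change of group on an aromatic carbon, so the stereocentre is a second place where the number moves beyond the scatter. The sulfonamide nitrogen is a third, since with the stereocentre drawn the same way the series gives a 4.6-fold lower number from compound 2 to compound 4 (0.66 log units; beyond the scatter), with 1,3-thiazol-2-yl in place of 5-fluoropyrimidin-2-yl.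

As far as these compounds go, it remains open whether the step between the two configurations keeps its direction and size with 5-fluoropyrimidin-2-yl on the sulfonamide nitrogen, or with 1,3-thiazol-2-yl on the aromatic carbon. From the compounds shown here alone, it is also open how the number would respond to a carboxylic acid in place of 2-methyl-1,3-oxazol-4-yl, or to an amine-bearing ring in place of 1,3-thiazol-2-yl on the sulfonamide nitrogen.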